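Swapping a Phenyl for a Hydroxyethyl Tail

This account rests on a few compounds, and the source may have more. Where it says the series, first, only, none or still open, it means among the compounds named here.

Measured so far:
compound 1 `CSc1nc(NCCCc2ccccc2)c2ccccc2n1` — 87800 nM
compound 2 `CSc1nc(NCc2ccc([Se]C)cc2)c2ccccc2n1` — a limit of the assay, > 100000 nM
compound 3 `Nc1nc([SeH])nc2ccccc12` — 52400 nM

In a functional assay on CCRF-CEM cells (Homo sapiens) for cytotoxicity, read by MTT assay, with a stated time of 72 h (on this read-out higher numbers stand for weaker inhibition of growth and lower numbers for stronger inhibition of growth), compound 1 gives 87800 nM, the highest of the two numbers reported. Compound 3 gives 52400 nM, which sits within the scatter of the number for compound 1, so no order between them can be read. The value for compound 2 is a limit, not a number (the limit of > 100000 nM in this assay, at which 1 of the 3 values shown sits).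

Compound 4 `CSc1nc(NCCCCCO)c2ccccc2n1` differs from compound 1 in one place: 2-hydroxyethyl in place of phenyl on a saturated chain carbon, three bonds along the chain from a nitrogen on an aromatic ring. Going by the values given here, no measured pair isolates this change. I expect the step from compound 1 to compound 4 to be a 1.3-fold higher number from compound 1 to compound 4 (0.10 log units; within the scatter), toward weaker growth inhibition but hardly beyond the scatter. Compound 4 is therefore estimated at 110000 nM, with a range from 40000 nM to 300000 nM.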

Compound 4, concentration for total growth inhibition: > 100000 nM
Compound 4: only a limit was reported (the forecaster's own chance of this, stated with the estimate: 50%); the middle value does not contradict the limit.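

In this assay, going by these compounds alone, 2-hydroxyethyl in place of phenyl gives an at least 1.1-fold higher number from compound 1 to compound 4 (0.05 log units; that floor lies within the scatter), the only step available at this position. Replacing the phenyl with this shorter tail brings no stronger growth inhibition, yet the floor of the step alone cannot show a real loss. Compound 4 reaches a limit of the assay, not a number, so the full size of the step stays unknown: the limit of > 100000 nM in this assay, at which 2 of the 4 values shown sit.

As far as these compounds go, whether an amine or a carboxylic acid in place of the hydroxyl would bring a number below the limit remains open. So does the effect of a longer chain carrying a phenyl.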